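From 2,5-dichlorobenzyl to 2,6-dichlorobenzyl: working notes

The compounds below may be only part of what the source reports. "The series", "measured", "known", "first", "only" and "open" are said of these compounds alone.

Measured in a functional assay on Jurkat cells (Homo sapiens); a lower number here means a stronger inhibitor, a higher number a weaker inhibitor:
compound 1 `C[C@H](NC(=O)C(=O)NCC1(c2ccccc2)CC1)C(=O)N[C@@H](CC(=O)O)C(=O)COc1c(F)c(F)cc(F)c1F`: 27 nM
compound 2 `C[C@H](NC(=O)C(=O)NCc1ccc(F)cc1)C(=O)N[C@@H](CC(=O)O)C(=O)COc1c(F)c(F)cc(F)c1F`: 197 nM
compound 3 `C[C@H](NC(=O)C(=O)NCc1cc(Cl)ccc1Cl)C(=O)N[C@@H](CC(=O)O)C(=O)COc1c(F)c(F)cc(F)c1F`: 4.3 nM

Compound 3 holds the lowest number of the three. Both steps leading to it lie beyond the scatter: a 6.3-fold lower number from compound 1 to compound 3 (0.80 log units; beyond the scatter), and a 46-fold lower number from compound 2 to compound 3 (1.66 log units; beyond the scatter). The change to compound 4 `C[C@H](NC(=O)C(=O)NCc1c(Cl)cccc1Cl)C(=O)N[C@@H](CC(=O)O)C(=O)COc1c(F)c(F)cc(F)c1F` is 2,6-dichlorophenyl in place of 2,5-dichlorophenyl on a saturated chain carbon bound to an amide-type nitrogen.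

For the measured compounds named here, no measured step isolates a change of this kind. The nearest evidence is the large step to compound 3 above, together with the modest 7.3-fold higher number from compound 1 to compound 2 (0.86 log units; beyond the scatter). These show that the group at this place can shift the number in this assay widely. A modest step towards a higher number is therefore expected, since compound 3 stands at the low end with 4.3 nM. The estimated change is a 2.3-fold higher number from compound 3 to compound 4 (0.37 log units; beyond the scatter). For compound 4 the expected value is 10 nM. The expected range for this estimate runs from 2.5 nM to 40 nM.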

Compound 4, half-maximal inhibitory concentration: 110 nM
Compound 4: middle estimate off by 11-fold (1.04 log units), on the low side; measured number outside the range, above it.
By their numbers in this assay, from the lowest: compound 3; then compound 1; then compounds 4 and 2 (each within the scatter of the next).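

In this assay, for the compounds shown here, the swap from 2,5-dichlorophenyl to 2,6-dichlorophenyl keeps the same atoms and counts yet gives a large step (a 26-fold higher number from compound 3 to compound 4 (1.41 log units; beyond the scatter)), so the arrangement of the two chlorines alone moves the number widely at this place, which the earlier compounds, each carrying a different group, could not show. Two chlorines do not by themselves secure a low number: compound 4 cannot be separated from the 4-fluorophenyl analogue (a 1.8-fold lower number from compound 2 to compound 4 (0.25 log units; within the scatter)) and falls on the weaker side of the 1-phenylcyclopropyl analogue (a 4.1-fold higher number from compound 1 to compound 4 (0.61 log units; beyond the scatter)). Nothing available explains why the arrangement matters so much.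

Still open, on these data alone, is whether the low number of compound 3 needs both chlorines, or whether a monochlorophenyl group would hold it. A dimethylphenyl or dibromophenyl group at this place would show whether chlorine itself is required.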